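The compounds below may be only part of what the source reports. "The series", "measured", "known", "first", "only" and "open" are said of these compounds alone.

Compounds measured so far in an assay on isolated protein for inhibition of aldehyde dehydrogenase 1A1 (Homo sapiens), read by spectrophotometry, tested at 10 uM; on this read-out lower numbers stand for less inhibition and higher numbers for more inhibition at the one concentration tested (going by the name of the read-out):

Compound 1 `Cc1cccc(Cn2c(CN3CCN(C(=O)c4ccc([N+](=O)[O-])cc4)CC3)nc3ccccc32)c1`; compound 1 gives 24.3%.
Compound 2 `COc1ccc(C(=O)N2CCN(Cc3nc4ccccc4n3Cc3cccc(C)c3)CC2)cc1`; compound 2 gives 55.5%.

Among the compounds with values here, compound 2 stands highest of the two numbers in this assay; its nearest neighbour is compound 1, and the one step between them, a number 31.2 percentage points higher from compound 1 to compound 2 (beyond the scatter), lies beyond the scatter. Within the data shown here, that step is the only measured comparison, and it concerns methoxy in place of nitro on an aromatic carbon.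

Compound 3 `Cc1cccc(Cn2c(CN3CCN(C(=O)c4ccc(F)cc4)CC3)nc3ccccc32)c1` differs from compound 2 as follows: fluoro in place of methoxy on an aromatic carbon. Among the measured compounds shown here, no measured step concerns fluoro in place of methoxy, so the one step on hand bears on it only indirectly: it shows that exchanging the group at this position can move this assay by a large amount, but it gives no direction for fluoro. Compound 3 is therefore expected to fall somewhere between the two measured numbers, with wide uncertainty, the step of a number 17.5 percentage points lower from compound 2 to compound 3 (beyond the scatter) being the estimate. For compound 3 the estimate in this assay is 38%, with a range from 12% to 64%.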

Compound 3, a percentage reported as inhibition, at one concentration (the size of the read-out at that concentration, not a potency): 27.1%
Compound 3: the middle estimate sits 10.9 percentage points above what was measured; low and high end bracket the measured number.
By their numbers in this assay, from the lowest: compounds 1 and 3 (each within the scatter of the next); then compound 2.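

In this assay, the exchange on the aromatic carbon para to a large group now has a second outcome, a number 28.4 percentage points lower from compound 2 to compound 3 (beyond the scatter), so the earlier gap is not peculiar to nitro: the 4-methoxyphenyl compound also stands apart from the 4-fluorophenyl compound. Nitro and fluoro do not separate, with a number 2.8 percentage points higher from compound 1 to compound 3 (within the scatter), so among these three compounds the number divides methoxy from the other two groups rather than forming a graded series, and no compound goes against that division. The change from methoxy to fluoro removes one carbon and the one hydrogen-bond acceptor counted for methoxy, but no accompanying measurement accounts for the difference in this read-out.

From the compounds shown here alone, whether the oxygen, the added carbon or the whole methoxy group carries the higher number remains open, and a hydroxyl, an amine or a longer chain such as ethoxy at this position would help separate these possibilities. Also open, going by these compounds, is whether the methoxy advantage holds when the 3-methylbenzyl group or another part of the shared core changes, since all three compounds differ only at this one position.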